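Replacing the Chain Group of Compound 3 to Give Compound 4

The source may report more compounds than this note shows. Statements on the series, on what has been measured and on what is new or still open speak of the compounds shown alone.

Compound 1 `Cc1c(C)c2c(c(C)c1O)CC[C@@](C)(CC[N+](C)(C)C)O2`: 2300 nM
Compound 2 `Cc1c(C)c2c(c(C)c1O)CC[C@](C)(CCN(C)C)O2`: 1000 nM
Compound 3 `Cc1c(C)c2c(c(C)c1O)CC[C@](C)(CC(=O)[N-][N+](C)(C)C)O2`: 8000 nM

Of the three measured compounds, compound 3 gives the highest number in a functional assay (brain) for inhibition, with Rattus norvegicus as the target; a lower number here means a stronger inhibitor, a higher number a weaker inhibitor; compound 1 lies nearest to it and compound 2 furthest. Compound 4 `Cc1c(C)c2c(c(C)c1O)CC[C@](C)(CC[N+](C)(C)C)O2` differs from compound 3 in one place: a group of 5 heavy atoms (4 carbon, 1 nitrogen; no ring) in place of a group of 7 heavy atoms (4 carbon, 2 nitrogen, 1 oxygen; no ring), on a saturated chain carbon bound to a saturated ring carbon. Among the measured compounds shown here, one measured step bears on this position, an 8.0-fold higher number from compound 2 to compound 3 (0.90 log units; beyond the scatter), a modest rise; compound 4 moves the other way, toward a smaller group that carries a charge. Compound 1 carries the same entering group on the other arrangement of the shared core and gives 2300 nM in this assay. Compound 4 is therefore expected to give a lower number than compound 3, estimated at 2500 nM with a range from 1000 nM to 6000 nM. That expected change amounts to a 3.2-fold lower number from compound 3 to compound 4 (0.51 log units; beyond the scatter).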

Compound 4, half-maximal inhibitory concentration: 2200 nM
Beside the measured number, compound 4's estimate is 1.1-fold (0.06 log units) above it; the measured number falls inside the stated range.
By their numbers in this assay, from the lowest: compound 2; then compounds 4 and 1 (each within the scatter of the next); then compound 3.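

In this assay, the charged group of compound 4 recovers much of what the larger group of compound 3 lost, with a 3.6-fold lower number from compound 3 to compound 4 (0.56 log units; beyond the scatter). It does not fully match the smaller group of compound 2, as a 2.2-fold higher number from compound 2 to compound 4 (0.34 log units; beyond the scatter) shows. The configuration at the ring carbon shows no effect for this charged group, with a 1.0-fold lower number from compound 1 to compound 4 (0.02 log units; within the scatter), and that pair isolates the stereocentre cleanly: the fact that compounds 1 and 4 differ only in the configuration as drawn

As far as these compounds go, whether the stereocentre matters equally with other groups stays open. So does how a carboxylic acid or a longer chain would behave at this place.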